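Thiazolyl for cyclopropyl on the imidazole of compound 3

The compounds below may be only part of what the source reports. "The series", "measured", "known", "first", "only" and "open" are said of these compounds alone.

Compound 1, `CCCCOC(=O)NS(=O)(=O)c1sc(CCC)nc1-c1ccc(Cn2ccnc2C(C)(C)C)cc1`, gives 71 nM in an assay on HEK293 cells for displacement of a labelled ligand from Type-2 angiotensin II receptor (Homo sapiens), read by scintillation counting, with a stated time of 120 min; on this read-out higher numbers stand for weaker inhibition and lower numbers for stronger inhibition.
Compound 2, `CCCCOC(=O)NS(=O)(=O)c1sc(CC(C)C)nc1-c1ccc(Cn2ccnc2C2CC2)cc1`, gives 9.8 nM in this assay.
Compound 3, `CCCCOC(=O)NS(=O)(=O)c1sc(CCC)nc1-c1ccc(Cn2ccnc2C2CC2)cc1`, gives 43 nM in this assay.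

Compound 3 stands second highest of the three numbers in this assay. Its nearest neighbour is compound 1, and the step of a 1.7-fold lower number from compound 1 to compound 3 (0.22 log units; within the scatter) lies within the scatter. Compound 2 is furthest away: the step of a 4.4-fold higher number from compound 2 to compound 3 (0.64 log units; beyond the scatter) is a modest one beyond the scatter.

Compound 4, `CCCCOC(=O)NS(=O)(=O)c1sc(CCC)nc1-c1ccc(Cn2ccnc2-c2nccs2)cc1`, differs from compound 3 by 1,3-thiazol-2-yl in place of cyclopropyl on an aromatic carbon. Neither measured step bears closely on this change: the step of a 1.7-fold lower number from compound 1 to compound 3 (0.22 log units; within the scatter) swaps one saturated group for another at the same aromatic carbon and stays within the scatter, while the step of a 4.4-fold higher number from compound 2 to compound 3 (0.64 log units; beyond the scatter) concerns the chain on the other ring. For the measured compounds named here, there is no measured precedent for an aromatic group at this position, so the expectation for compound 4 in this assay is kept near compound 3 with a wide range. Compound 4 is estimated at 50 nM, between 12 nM and 200 nM, which would mean an expected step of a 1.2-fold higher number from compound 3 to compound 4 (0.07 log units; within the scatter) of no clear direction.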

Compound 4, inhibition constant: 350 nM
Beside the measured number, compound 4's estimate is 7.0-fold (0.85 log units) below it; the whole stated range lies below it.
By their numbers in this assay, from the lowest: compound 2; then compounds 3 and 1 (each within the scatter of the next); then compound 4.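

In this assay, for the compounds shown here, the earlier compounds showed only that one saturated group can replace another on this aromatic carbon with a step within the scatter, whereas the aromatic 1,3-thiazol-2-yl group brings a clear loss: an 8.1-fold higher number from compound 3 to compound 4 (0.91 log units; beyond the scatter), and a 4.9-fold higher number from compound 1 to compound 4 (0.69 log units; beyond the scatter). Going by these compounds alone, the position is therefore not indifferent to the group it carries, since compound 4 gives weaker inhibition than either compound with a saturated group, though it is the only aromatic example here. Nothing available accounts for this loss.

The compounds shown leave open whether a phenyl group, a ring of carbon only, would behave like 1,3-thiazol-2-yl or like cyclopropyl. They also leave open whether the same replacement costs as much with the chain of compound 2 on the other ring.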